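Isobutyl in place of tert-butyl: expected clearance

This account rests on a few compounds, and the source may have more. Where it says the series, first, only, none or still open, it means among the compounds named here.

Measured in an ADME assay on microsomes from liver (Homo sapiens) for metabolic stability; a higher number here means faster removal of the compound, a lower number slower removal
compound 1 `O=C(O)CCNC(=O)c1ccc(C(Oc2ccc(-n3cc(C(F)(F)F)cn3)cc2)C2CC2)cc1` gives < 8 mL/min/kg as a limit
compound 2 `O=C(O)CCNC(=O)c1ccc(C(Oc2ccc(-n3cc(C(F)(F)F)cn3)cc2)C2CCC2)cc1` gives 26 mL/min/kg as a number
compound 3 `CC(C)(C)C(Oc1ccc(-n2cc(C(F)(F)F)cn2)cc1)c1ccc(C(=O)NCCC(=O)O)cc1` gives 31 mL/min/kg as a number

Compound 3 stands level with compound 2 (a 1.2-fold higher number from compound 2 to compound 3 (0.08 log units; within the scatter)). Compound 1 alone stands at a limit (the limit of < 8 mL/min/kg in this assay, at which 1 of the 3 values shown sits). The steps away from that limit are larger (an at least 3.2-fold higher number from compound 1 to compound 2 (0.51 log units; beyond the scatter); an at least 3.8-fold higher number from compound 1 to compound 3 (0.58 log units; beyond the scatter)). Compound 4 `CC(C)CC(Oc1ccc(-n2cc(C(F)(F)F)cn2)cc1)c1ccc(C(=O)NCCC(=O)O)cc1` has isobutyl in place of tert-butyl on a saturated chain carbon bound to an aromatic carbon and an oxygen on an aromatic ring. The closest guide is the exchange of cyclobutyl for tert-butyl between compound 2 and compound 3 (a 1.2-fold higher number from compound 2 to compound 3 (0.08 log units; within the scatter)). No step beyond the scatter is therefore expected (a 1.0-fold lower number from compound 3 to compound 4 (0.01 log units; within the scatter)). Compound 4 is estimated at 30 mL/min/kg (expected range 14 mL/min/kg to 60 mL/min/kg).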

Compound 4, clearance: 23 mL/min/kg
Beside the measured number, compound 4's estimate is 1.3-fold (0.12 log units) above it, within the range that was stated.
By their numbers in this assay, from the lowest: compounds 4, 2 and 3 (each within the scatter of the next). At a limit, below all of these: compound 1.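

In this assay, isobutyl in place of tert-butyl, the same atoms joined differently, gives a 1.3-fold lower number from compound 3 to compound 4 (0.13 log units; within the scatter), and isobutyl in place of cyclobutyl gives a 1.1-fold lower number from compound 2 to compound 4 (0.05 log units; within the scatter), so an open, branched chain at this position reads level with both earlier groups. Isobutyl in place of cyclopropyl gives an at least 2.8-fold higher number from compound 1 to compound 4 (0.45 log units; beyond the scatter), which leaves cyclopropyl alone apart from the other three groups. The value of compound 1 is a limit, not a number: the limit of < 8 mL/min/kg in this assay, at which 1 of the 4 values shown sits.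

Open, as far as these compounds go, is whether isopropyl or cyclopentyl at this position would read with cyclopropyl or with the other three groups. Also open, from the compounds shown here alone, is how far the true value of compound 1 lies from its limit.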